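This account rests on a few compounds, and the source may have more. Where it says the series, first, only, none or still open, it means among the compounds named here.

The measured compounds:
Compound 1, `COc1ccc(Cc2c(C)[nH]n(-c3nc4ccccc4[nH]3)c2=O)cc1`, gives 630 nM in an assay on isolated protein for inhibition of alpha-ketoglutarate-dependent dioxygenase alkB homolog 3 (Homo sapiens), read by polymerase chain reaction, with a stated time of 1 h; a lower number here means a stronger inhibitor, a higher number a weaker inhibitor.
Compound 2, `Cc1[nH]n(-c2nc3ccccc3[nH]2)c(=O)c1CC(=O)O`, gives 15000 nM in this assay.
Compound 3, `Cc1[nH]n(-c2nc3ccccc3[nH]2)c(=O)c1Cc1ccc(Cl)cc1Cl`, gives only a limit of the assay in this assay, > 10000 nM.

Compound 3 therefore stands at the limit, where (the limit of > 10000 nM in this assay, at which 1 of the 3 values shown sits). The step to compound 4, `COC(=O)Cc1c(C)[nH]n(-c2nc3ccccc3[nH]2)c1=O`, is methoxycarbonyl in place of 2,4-dichlorophenyl on a saturated chain carbon bound to an aromatic carbon. Within the data shown here, two measured steps bear on it. The step of an at least 15-fold higher number from compound 1 to compound 3 (1.20 log units; beyond the scatter) shows how far the 2,4-dichlorophenyl compound falls behind compound 1, and the step of a 24-fold higher number from compound 1 to compound 2 (1.38 log units; beyond the scatter) shows that the carboxy compound 2 also falls far behind compound 1. The step that the limit leaves unreadable from compound 2 to compound 3 cannot be read because of the limit. Methoxycarbonyl is closest in kind to the carboxy group of compound 2, whose value of 15000 nM is the nearest guide. Compound 4 is thus expected to remain a weak inhibitor, near compound 2, so that the step of a number no higher from compound 3 to compound 4 (the limit leaves the size open) is expected to be small or unreadable. The estimate for compound 4 in this assay is 10000 nM, with a range from 3000 nM to 30000 nM.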

Compound 4, half-maximal inhibitory concentration: 4300 nM
Compound 4: middle estimate off by 2.3-fold (0.37 log units), on the high side, within the range that was stated.
By their numbers in this assay, from the lowest: compound 1; then compound 4; then compound 2.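

At the saturated chain carbon bound to an aromatic carbon, methyl in place of hydrogen on an oxygen next to a carbonyl group gives a 3.5-fold lower number from compound 2 to compound 4 (0.54 log units; beyond the scatter) in this assay, so this small change on the side chain can be read in the assay. Methoxycarbonyl still trails the 4-methoxyphenyl group, with a 6.8-fold higher number from compound 1 to compound 4 (0.83 log units; beyond the scatter), so the ringless methoxycarbonyl group does not match compound 1. Methoxycarbonyl in place of 2,4-dichlorophenyl gives an at least 2.3-fold lower number from compound 3 to compound 4 (0.36 log units; beyond the scatter), which shows that a phenyl ring at this place does not by itself outdo methoxycarbonyl, although compound 3 gives only a limit of the assay, so this step has no fixed size: the limit of > 10000 nM in this assay, at which 1 of the 4 values shown sits.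

From the compounds shown here alone, the step from compound 2 to compound 3 cannot be read, so the order of those two stays open. Going by these compounds, it also remains open whether an amide, an ethoxycarbonyl group or a longer chain at this place would come closer to compound 1.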